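The source may hold more compounds than are shown below. What is called first, only, known or untested is meant among the compounds shown, and "the series" means these compounds.

Compound 1 (`Cc1cc(C)c2nc(-c3cc4ccccc4n3Cc3ccccc3)[nH]c2c1`) gives 21800 nM
Compound 2 (`Cc1cccc2[nH]c(-c3cc4ccccc4[nH]3)nc12`) gives 8900 nM

Both values come from a functional assay on T47D cells (Homo sapiens) for antiproliferative activity, read by MTT assay, with a stated time of 48 h; a lower number here means a stronger inhibitor, a higher number a weaker inhibitor. Compound 2 has the lower of the two numbers (8900 nM) and is thus the stronger inhibitor. Compound 1 stands higher (21800 nM), and that gap lies beyond the usual scatter of repeated measurements.

Compound 3 (`Cc1cc(C)c2nc(-c3cc4ccccc4[nH]3)[nH]c2c1`) has not yet been measured in this assay. It departs from compound 2 by a single change (methyl in place of hydrogen on an aromatic carbon), with methyl in place of hydrogen on an aromatic carbon of a six-membered aromatic ring of carbon only, meta to a methyl group.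

Within the data shown here, no pair of measured compounds differing in one place is available, so the data give no direction for this change. With so small an addition and no evidence either way, no shift beyond the scatter is expected. The estimated step (a 1.1-fold lower number from compound 2 to compound 3 (0.05 log units; within the scatter)) is therefore expected to be small. Compound 3 is expected at 8000 nM, with an estimated range from 3200 nM to 20000 nM as its span.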

Compound 3, half-maximal inhibitory concentration: 24800 nM
Beside the measured number, compound 3's estimate is 3.1-fold (0.49 log units) below it; measured number above the stated range.
By their numbers in this assay, from the lowest: compound 2; then compounds 1 and 3 (each within the scatter of the next).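

In this assay the added methyl, on an aromatic carbon meta to a methyl group, proves not to be a silent change: it gives a 2.8-fold higher number from compound 2 to compound 3 (0.45 log units; beyond the scatter), so this position does respond, and the response is a loss of strength. The other step, a 1.1-fold higher number from compound 1 to compound 3 (0.06 log units; within the scatter), comes with hydrogen in place of benzyl on an aromatic nitrogen and stays within the scatter, so on this methyl-bearing core the benzyl group makes no readable difference to the number. Nothing at hand accounts for either step.

On these data alone, it remains open whether the loss belongs to methyl alone or would also come with another group at this place, such as a chlorine, a methoxy or an amine, and a hydrogen at this place is so far compared only with the one methyl. Among these compounds, it is also open whether benzyl on the aromatic nitrogen would stay equally without effect on the core of compound 2, since the single pair that carries this change has the added methyl in both its members.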